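Iodo in Place of Chloro: What to Expect of Compound 4

A few compounds are considered here, and "the series" means these few. Any claim that something is new, unique, unknown or untested is made for them only; others in the source may bear on it.

Compound 3 `CCc1nn(C)c(CO/N=C/c2c(C)nn(C)c2Oc2ccc(Cl)cc2)c1Cl` is known in a functional assay on SMMC-7721 cells (Homo sapiens) for inhibition, read by MTT assay, with a stated time of 72 h, tested at 25 uM (a higher number here means more inhibition at the concentration tested (going by the name of the read-out), a lower number less inhibition), only as a limit: compound 3 gives < 80%, a limit of the assay rather than a number (the limit of < 80% in this assay, at which 1 of the 3 values shown sits). Compound 4 `CCc1nn(C)c(CO/N=C/c2c(C)nn(C)c2Oc2ccc(I)cc2)c1Cl` differs from it by iodo in place of chloro on an aromatic carbon. Of the measured steps, only the halogen exchange on the same ring bears on this change: compound 1 `Cc1nn(C)c(Oc2ccc(F)cc2)c1/C=N\OCc1c(Cl)c(-c2ccc(F)cc2)nn1C` gives 80%, compound 2 `Cc1nn(C)c(Oc2ccc(Cl)cc2)c1/C=N\OCc1c(Cl)c(-c2ccc(F)cc2)nn1C` gives 80%, and the step of no change at the digits printed from compound 1 to compound 2 (within the scatter). A halogen exchange at this place thus left the read-out unchanged within the scatter, so for compound 4 a step that the limit leaves unreadable from compound 3 to compound 4 is expected, none beyond the scatter. Compound 4 is estimated at 55%, between 25% and 78%, with a fair chance that only a limit is reported again.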

Compound 4, a percentage reported as inhibition, at one concentration (the size of the read-out at that concentration, not a potency): < 80%
Compound 4: only a limit was reported; the forecaster's own chance of this, stated with the estimate: 55%; the middle value is on the limit's open side.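

For the compounds shown here, compound 3 and compound 4 are both reported only as limits, so no step between them can be read: the limit of < 80% in this assay, at which 2 of the 4 values shown sit. The compounds shown leave open whether iodo in place of chloro on an aromatic carbon changes the inhibition at all.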